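A Cyano Swap With Little Data to Lean On

The source may hold more compounds than are shown below. What is called first, only, known or untested is meant among the compounds shown, and "the series" means these compounds.

Two related structures come first. In an ADME assay on Caco-2 cells (Homo sapiens) for permeability, in the apical to basolateral direction (on this read-out higher numbers stand for higher permeability and lower numbers for lower permeability), compound 1 (`CC(=O)N1CCN(c2cccc(-c3cc(-c4cnc(Cl)n4C)c4c(N)ncnn34)c2)C(=O)C1(C)C`) gives < 36 nm/s as a limit of the assay, not a number. For compound 2 (`CC(=O)N1CCN(c2cccc(-c3cc(-c4cc(C(C)C)no4)c4c(N)ncnn34)c2)C(=O)C1(C)C`) the entry reads "not determined" (no result reported) and so offers no number at all. The next structure is compound 3 (`CC(=O)N1CCN(c2cccc(-c3cc(C#N)c4c(N)ncnn34)c2)C(=O)C1(C)C`). The change is cyano in place of 3-isopropyl-1,2-oxazol-5-yl on an aromatic carbon and puts cyano in place of 3-isopropyl-1,2-oxazol-5-yl on an aromatic carbon. For the measured compounds named here, no measured pair shows what such a swap does in this assay, and compound 2 cannot serve as a starting point. Going by the values given here, the only anchor is compound 1 with the limit of < 36 nm/s in this assay, at which 1 of the 2 values shown sits, as its sole reference. A modest upward step from that limit is expected, not far beyond the usual scatter. Compound 3 is estimated at 70 nm/s with an expected range of 22 nm/s to 220 nm/s in this measurement.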

Compound 3, apparent permeability: 84 nm/s
The estimate for compound 3 lay 1.2-fold (0.08 log units) below the measured number, and the stated range covers the measured number.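

At this aromatic carbon, two ring bonds from the ring nitrogen, cyano in place of 2-chloro-1-methyl-1H-imidazol-5-yl gives an at least 2.3-fold higher number from compound 1 to compound 3 (0.36 log units; beyond the scatter) in this assay as a readable result. Compound 3 gives this position an actual number, showing that a group with no ring on this carbon can read clear of the limit. The true size of the step stays unknown because compound 1 carries a limit of the assay, not a number: the limit of < 36 nm/s in this assay, at which 1 of the 3 values shown sits.

Going by these compounds, compound 2 has no reported result, so the steps that involve it cannot be read, and what its 3-isopropyl-1,2-oxazol-5-yl group does here stays open. Also open, on these data alone, is how an amine, a carboxylic acid or a plain methyl on this same carbon would read in this assay, since one step from a single pair sets no trend.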